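Cycloalkyl ether swap on a shared oxazoline aniline core

The source may report more compounds than this note shows. Statements on the series, on what has been measured and on what is new or still open speak of the compounds shown alone.

Compound 1 `c1cc(OC2CCCC2)ccc1NC1=NCCO1` and compound 3 `c1cc(OC2CCCCC2)ccc1NC1=NCCO1` share one core. Compound 2 `c1cc(NC2=NCCO2)cc(OC2CCCC2)c1` is built from the same atoms as compound 1, joined differently; the difference between the two cores is not broken down here. In a functional assay on HT-29 cells (Homo sapiens) for inhibition, read by sulforhodamine B assay, with a stated time of 48 h (a lower number here means a stronger inhibitor of growth, a higher number a weaker inhibitor of growth), compound 1 gives 16100 nM, compound 3 gives 12600 nM and compound 2 gives 52200 nM. The change from compound 1 to compound 3 is cyclohexyl in place of cyclopentyl on an oxygen on an aromatic ring, and it made a 1.3-fold lower number from compound 1 to compound 3 (0.11 log units; within the scatter). Compound 2 sits beyond the scatter above both compound 1 and compound 3.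

Compound 4 `c1cc(NC2=NCCO2)cc(OC2CCCCC2)c1` is not yet measured. It differs from compound 2 by cyclohexyl in place of cyclopentyl on an oxygen on an aromatic ring, the same change as between compound 1 and compound 3, with the same surroundings at the place. The only earlier occurrence of this change is a 1.3-fold lower number from compound 1 to compound 3 (0.11 log units; within the scatter), a step inside the scatter. A step of that kind is expected again, so compound 4 is expected to show a 1.3-fold lower number from compound 2 to compound 4 (0.10 log units; within the scatter). Compound 4 is accordingly estimated at 41000 nM in this assay. The expected range for compound 4 runs from 20000 nM to 90000 nM, wide because it rests on one prior step a 1.3-fold lower number from compound 1 to compound 3 (0.11 log units; within the scatter) and a weak parent.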

Compound 4, concentration for 50% growth inhibition: 4400 nM
Compound 4: middle estimate off by 9.3-fold (0.97 log units), on the high side; the measured number lies below the stated range.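

On the core of compound 2, cyclohexyl in place of cyclopentyl on the oxygen gives a 12-fold lower number from compound 2 to compound 4 (1.07 log units; beyond the scatter) in this assay, so the result for this change on the core of compound 1 did not predict its size here. The step therefore does not carry over at a fixed size between these two cores: the same change on two cores in this assay, a 1.3-fold lower number (0.11 log units; within the scatter) from compound 1 to compound 3 and a 12-fold lower number (1.07 log units; beyond the scatter) from compound 2 to compound 4, 9.3-fold (0.97 log units) apart, beyond the scatter of two such steps
This rests on a single pair for each core, so it shows that the size of the step can depend on the core, but it does not give the reason for the gap or a rule for any other core.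

As far as these compounds go, it remains open whether the larger step on the core of compound 2 would continue with a cycloheptyl group or would also appear with an open chain such as n-hexyl on the same oxygen. From the compounds shown here alone, it is also open whether the two cores would again part with a smaller group, such as methyl or cyclobutyl, in that place.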